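The source may report more compounds than this note shows. Statements on the series, on what has been measured and on what is new or still open speak of the compounds shown alone.

Of the compounds shown here, three have been measured so far in an assay on CHO cells for displacement of a labelled ligand from Substance-P receptor (Homo sapiens); on this read-out higher numbers stand for weaker inhibition and lower numbers for stronger inhibition. Compound 1 `c1ccc(C2CCC3(OCCNC3c3ccccc3)OC2)cc1` gives 170 nM in this assay, and compound 3 `Fc1ccc(C2NCCOC23CCC(c2cccc(C(F)(F)F)c2)CO3)cc1` gives 513 nM. Compound 2 `COc1ccc(C(C)C)cc1[C@H]1COCC2(C1)OCCN[C@H]2c1ccc(F)cc1` stands lowest of the three with 2.8 nM; its gaps to compound 1 and to compound 3 both lie beyond the usual scatter of this assay, so compound 2 is the strongest inhibitor among them.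

Compound 4 `COc1ccccc1[C@H]1COCC2(C1)OCCN[C@H]2c1ccc(F)cc1` has not yet been measured. It differs from compound 2 in one place: hydrogen in place of isopropyl on an aromatic carbon. Among the compounds with values here, no pair of measured compounds differing in a single place is available, so the size of this step can only be guessed. Taking away a group from the aromatic ring of the most potent compound seems more likely to weaken than to strengthen inhibition, and a moderate loss, larger than the scatter, is the expectation here.

Compound 4 is therefore expected to give about 15 nM in this assay, somewhere between 4 nM and 60 nM. That corresponds to an estimated step of a 5.4-fold higher number from compound 2 to compound 4 (0.73 log units; beyond the scatter).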

Compound 4, half-maximal inhibitory concentration: 13 nM
The estimate for compound 4 lay 1.2-fold (0.06 log units) above the measured number; measured number inside the range.
By their numbers in this assay, from the lowest: compound 2; then compound 4; then compound 1; then compound 3.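

Going from isopropyl to hydrogen gives the first single-place step in this assay, a 4.6-fold higher number from compound 2 to compound 4 (0.67 log units; beyond the scatter), showing that this position on the aromatic ring affects inhibition. The change removes the three carbons of the isopropyl group, yet compound 4 still gives 13 nM, so the isopropyl group adds to inhibition without accounting for all of it. Nothing at hand explains the size of this step.

Going by these compounds, with only isopropyl and hydrogen compared at this position, it remains open whether a smaller methyl group would recover part of the difference, or whether a larger tert-butyl group or a chlorine atom would match or exceed isopropyl. On these data alone, it is also open whether the same change would have a similar effect in compounds with a different aromatic group on the shared core.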